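The compounds below may be only part of what the source reports. "The series", "measured", "known", "first", "only" and "open" are said of these compounds alone.

Measured so far:
compound 1 `O=C(Nc1cccc(-n2cc(-c3ccncc3)c(-c3ccc(Cl)c(O)c3)n2)c1)Nc1ccc(Cl)c(Cl)c1` — 1030 nM
compound 2 `O=C(Nc1cccc(-n2cc(-c3ccncc3)c(-c3ccc(Cl)c(O)c3)n2)c1)Nc1cc(C(F)(F)F)cc(C(F)(F)F)c1` — 789 nM

Both compounds were tested in a functional assay on CCRF-CEM cells (Homo sapiens) for inhibition, read by sulforhodamine B assay, with a stated time of 48 h; on this read-out higher numbers stand for weaker inhibition of growth and lower numbers for stronger inhibition of growth. In this assay compound 1 gives 1030 nM and compound 2 gives 789 nM; the gap between these two numbers lies within the usual scatter of repeated measurements, so on the data in hand compound 1 and compound 2 cannot be told apart. Compound 3 `O=C(Nc1cccc(-n2cc(-c3ccncc3)c(-c3ccc(Cl)c(O)c3)n2)c1)Nc1ccc(Cl)c(C(F)(F)F)c1` has not yet been measured. It differs from compound 1 in one place: trifluoromethyl in place of chloro on an aromatic carbon. For the measured compounds named here, no step between two measured compounds carries this change, so the only guide is compound 2, which also carries trifluoromethyl groups and gives 789 nM, a number within the scatter of compound 1. The step from compound 1 to compound 3 is therefore expected to be small, a 1.2-fold lower number from compound 1 to compound 3 (0.08 log units; within the scatter), with no direction that rises above the scatter. For compound 3 the estimate is 850 nM, with a range from 400 nM to 1800 nM.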

Compound 3, concentration for 50% growth inhibition: 719 nM
Estimate against measurement, compound 3: 1.2-fold (0.07 log units) above; low and high end bracket the measured number.
By their numbers in this assay, from the lowest: compounds 3, 2 and 1 (each within the scatter of the next).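

For the compounds shown here, the only direct comparison at this position is the replacement of 3,4-dichlorophenyl by 4-chloro-3-(trifluoromethyl)phenyl, which in this assay gives a 1.4-fold lower number from compound 1 to compound 3 (0.16 log units; within the scatter). Compound 2 could not show this, since it differs from compound 1 in more than one place. Here, one chloro gives way to a trifluoromethyl group of four heavy atoms with the rest of the molecule unchanged, and this read-out cannot tell the two compounds apart, so both groups fit at this spot as far as growth inhibition in these cells shows; nothing on hand explains this result.

Still open, as far as these compounds go, is whether a group of a different kind here, such as an amine, a carboxylic acid or a methoxy group, would move the number beyond the scatter. Also open, from the compounds shown here alone, is what happens when the remaining chloro group is replaced by a hydrogen or a methyl group.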